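Series notes: aryl swap from compound 3 to compound 4

This account rests on a few compounds, and the source may have more. Where it says the series, first, only, none or still open, it means among the compounds named here.

Compound 1 `S=C(Nc1ccccc1)N1N=C(c2ccccc2)CC1c1ccc2c(c1)OCCO2` gives 6630 nM in a functional assay on HT-29 cells (Homo sapiens) for antiproliferative activity, read by MTT assay, with a stated time of 48 h; on this read-out lower numbers stand for stronger inhibition of growth and higher numbers for weaker inhibition of growth. Compound 2 `Fc1ccc(C2=NN(C(=S)Nc3ccccc3)C(c3ccc4c(c3)OCCO4)C2)cc1` gives 37600 nM in this assay, a step of a 5.7-fold higher number from compound 1 to compound 2 (0.75 log units; beyond the scatter). Compound 3 `O=[N+]([O-])c1ccc(C2=NN(C(=S)Nc3ccccc3)C(c3ccc4c(c3)OCCO4)C2)cc1` gives 153000 nM, the highest of the three numbers, reached by steps of a 23-fold higher number from compound 1 to compound 3 (1.36 log units; beyond the scatter) and a 4.1-fold higher number from compound 2 to compound 3 (0.61 log units; beyond the scatter). Compound 4 `S=C(Nc1ccccc1)N1N=C(c2ccccc2Br)CC1c1ccc2c(c1)OCCO2` differs from compound 3 by 2-bromophenyl in place of 4-nitrophenyl on a carbon with a double bond to nitrogen. The step from compound 1 to compound 3, read in reverse, bears most directly: removing the nitro is expected to bring the number down strongly, because a 23-fold higher number from compound 1 to compound 3 (1.36 log units; beyond the scatter) was large. Within the data shown here, a fluoro entering the phenyl gave a 5.7-fold higher number from compound 1 to compound 2 (0.75 log units; beyond the scatter), so the entering bromo may hold part of that back, though no measured step covers bromo. Compound 4 is therefore expected at a 10-fold lower number from compound 3 to compound 4 (1.01 log units; beyond the scatter), around 15000 nM, within 4000 nM to 60000 nM.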

Compound 4, concentration for 50% growth inhibition: > 200000 nM
Compound 4: a limit, no number; the forecaster's own chance of this, stated with the estimate: 5%; middle value at least 13-fold (1.12 log units) from the limit.
By their numbers in this assay, from the lowest: compound 1; then compound 2; then compound 3. At a limit, above all of these: compound 4.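

In this assay compound 4 gives > 200000 nM, a limit of the assay and not a number. Every substituted phenyl on this carbon now reads weaker than the plain phenyl, with an at least 30-fold higher number from compound 1 to compound 4 (1.47 log units; beyond the scatter) and an at least 5.3-fold higher number from compound 2 to compound 4 (0.72 log units; beyond the scatter), so the loss extends to a 2-bromophenyl and is not confined to 4-fluorophenyl and 4-nitrophenyl. The remaining comparison gives an at least 1.3-fold higher number from compound 3 to compound 4 (0.11 log units; that floor lies within the scatter), so no order can be stated for that pair. On these data alone, whether a phenyl carrying an amine or a hydroxyl would keep or improve on the growth inhibition of the plain phenyl stays open.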